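Swapping Benzyl for Cyclopentyl: Expected Cell Toxicity

This account rests on a few compounds, and the source may have more. Where it says the series, first, only, none or still open, it means among the compounds named here.

Of the compounds shown here, three sharing one core have been tested in an ADME assay on BCBL1 cells (Homo sapiens) for cytotoxicity, with a stated time of 7 days; on this read-out lower numbers stand for higher toxicity in this test and higher numbers for lower toxicity in this test. Compound 2 `Nc1nc(NCc2ccccc2)c2ncn(/C=C3/CC3(CO)CO)c2n1` carries a benzyl group on a nitrogen on an aromatic ring, and in this assay compound 2 gives 19900 nM, the only result reported as a number. Compound 1 `Nc1nc(NC2CCCCC2)c2ncn(/C=C3/CC3(CO)CO)c2n1` carries cyclohexyl on that same nitrogen. For compound 1 the result in this assay is a limit, > 20000 nM. Compound 3 `Nc1nc2c(ncn2/C=C2/CC2(CO)CO)c(=O)[nH]1` has a ring carbonyl in place of the amino group. For compound 3 the result in this assay is likewise a limit, > 20000 nM. The step of a number no higher from compound 1 to compound 2 (the limit leaves the size open) cannot be sized because the limit of > 20000 nM in this assay, at which 2 of the 3 values shown sit, hides how far beyond the number compound 1 actually lies.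

Compound 4 `Nc1nc(NC2CCCC2)c2ncn(/C=C3/CC3(CO)CO)c2n1` differs from compound 2 by cyclopentyl in place of benzyl on a nitrogen on an aromatic ring. Among the compounds with values here, this roughly mirrors the only measured step, which replaced a saturated ring with benzyl and gave a change too small to read. The data point to no direction, so no step beyond the usual scatter is expected. Compound 4 is expected to give 20000 nM in this assay, between 10000 nM and 40000 nM, which means an expected step of a 1.0-fold higher number from compound 2 to compound 4 (0.00 log units; within the scatter), and the result may well come back only as a limit.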

Compound 4, half-maximal cytotoxic concentration: 71700 nM
For compound 4 the middle estimate is 3.6-fold (0.55 log units) below the measured one; the measured number lies above the stated range.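

In this assay, the group on this nitrogen on an aromatic ring can clearly move the read-out: cyclopentyl in place of benzyl gives a 3.6-fold higher number from compound 2 to compound 4 (0.56 log units; beyond the scatter), and a higher number here stands for lower toxicity in this test. Within the data shown here, the earlier compounds could not show this, since their only step had no readable size, whereas this step is a modest one beyond the usual scatter and rests on two reported numbers. Compound 1 is reported only as a limit, so neither step that involves it can be read, and the comparison of cyclopentyl with cyclohexyl stays without a size: the limit of > 20000 nM in this assay, at which 2 of the 4 values shown sit.

Among these compounds, the single readable step swaps a benzyl group for a cyclopentyl group, so it cannot separate the loss of the six-membered aromatic ring from the change in the number of carbons or the move to a five-membered ring. A cyclobutyl group, a phenyl group set directly on the nitrogen, or an open chain such as isopropyl on this nitrogen would help to pull these apart.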